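The source may report more compounds than this note shows. Statements on the series, on what has been measured and on what is new or still open speak of the compounds shown alone.

Compound 1, `COc1ccc(Nc2nc(-c3cccc(F)c3)nc3ccc(F)cc23)cc1`, carries a 4-methoxyphenyl group on the nitrogen of its core, and in a functional assay on HT29-AK cells (Homo sapiens) for cytotoxicity, read by MTT assay, with a stated time of 48 h (a lower number here means a stronger inhibitor, a higher number a weaker inhibitor), compound 1 gives 42300 nM. Compound 2, `Fc1ccc(Nc2nc(-c3cccc(F)c3)nc3ccc(F)cc23)cc1`, carries a 4-fluorophenyl group on that nitrogen instead. In this assay compound 2 reaches only the limit of the measurement, > 50000 nM. Compound 3, `Fc1cccc(-c2nc(Nc3ccccc3Cl)c3cc(F)ccc3n2)c1`, carries a 2-chlorophenyl group on the same nitrogen. For compound 3 this assay likewise reports only a limit, > 50000 nM. Two of the three values thus sit at the limit of > 50000 nM in this assay, at which 2 of the 3 values shown sit. Compound 2 therefore stands at the upper edge of what this assay can read, without a number of its own.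

Compound 4, `Oc1ccccc1Nc1nc(-c2cccc(F)c2)nc2ccc(F)cc12`, is the next variation: 2-hydroxyphenyl in place of 4-fluorophenyl on a nitrogen on an aromatic ring. The measured steps that touch the group on this nitrogen are thin. There is an at least 1.1-fold higher number from compound 1 to compound 3 (0.07 log units; that floor lies within the scatter), and a step that the two limits leave unreadable from compound 2 to compound 3. For comparison, an at least 1.1-fold higher number from compound 1 to compound 2 (0.07 log units; that floor lies within the scatter). None of these shows a direction or a size beyond the scatter, and all three measured compounds are weak in this assay. Compound 4 is accordingly expected to stay near the limit, and the step of a number no higher from compound 2 to compound 4 (the limit leaves the size open) is estimated as none beyond the scatter. The estimate for compound 4 is 50000 nM, within a range of 20000 nM to 150000 nM.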

Compound 4, half-maximal inhibitory concentration: > 50000 nM
Compound 4 was reported as a limit; the forecaster's own chance of this, stated with the estimate: 60%; the middle value sits exactly at the limit.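

Compound 4 is reported in this assay only as a limit, > 50000 nM. Among these compounds, the group on this nitrogen now counts a hydrogen-bond donor and a hydrogen-bond acceptor where 4-fluorophenyl counted none, yet the only step with a floor, an at least 1.1-fold higher number from compound 1 to compound 4 (0.07 log units; that floor lies within the scatter), shows nothing beyond the scatter, and the steps that link compound 4 with compound 2 and with compound 3 cannot be read. The change therefore adds a hydroxy group to the variations at this position without yielding a number, and the results gather further at one value: the limit of > 50000 nM in this assay, at which 3 of the 4 values shown sit.

As far as these compounds go, how far compound 2, compound 3 and compound 4 lie from one another stays open, since none of the three has a number of its own. Among the compounds shown here, also open is whether an amine or a carboxylic acid on this phenyl ring, or a longer chain on the nitrogen in its place, would move the reading clearly away from the one measured number, the 42300 nM of compound 1.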